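The source may report more compounds than this note shows. Statements on the series, on what has been measured and on what is new or still open speak of the compounds shown alone.

Measured compounds:
- compound 1, `CO[C@H]1CC[C@@H](Nc2cc(NCc3cnccc3C(F)(F)F)ncc2C#N)CC1` — in an assay on isolated protein for inhibition of protein kinase C theta type (Homo sapiens), read by TR-FRET, with a stated time of 2 h (on this read-out lower numbers stand for stronger inhibition and higher numbers for weaker inhibition), compound 1 gives 58 nM
- compound 2, `CO[C@H]1CC[C@@H](CNc2cc(NCc3cnccc3C(F)(F)F)ncc2C#N)CC1` — in this assay compound 2 gives 70 nM
- compound 3, `CNC(=O)[C@H]1CC[C@@H](Nc2cc(NCc3cnccc3C(F)(F)F)ncc2C#N)CC1` — in this assay compound 3 gives 27 nM

Among these three, compound 3 has the lowest number: the step of a 2.1-fold lower number from compound 1 to compound 3 (0.33 log units; beyond the scatter) and the step of a 2.6-fold lower number from compound 2 to compound 3 (0.41 log units; beyond the scatter) both lie beyond the scatter, so compound 3 is the strongest inhibitor of the set. Compound 1 and compound 2 sit within the scatter of each other, as the step of a 1.2-fold higher number from compound 1 to compound 2 (0.08 log units; within the scatter) shows.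

Compound 4, `N#Cc1cnc(NCc2cnccc2C(F)(F)F)cc1N[C@H]1CC[C@@H](n2cncn2)CC1`, keeps the shared core of compound 3 and alters only the group on the saturated ring: 1H-1,2,4-triazol-1-yl in place of methylcarbamoyl on a saturated ring carbon. Going by the values given here, the one measured step that touches the same position is a 2.1-fold lower number from compound 1 to compound 3 (0.33 log units; beyond the scatter), where a methoxy gave way to a methylcarbamoyl and the number fell modestly. Among the compounds with values here, no measured pair shows what an aromatic five-membered ring at this position does, so the expectation rests on the observation that changes here have so far moved the number only modestly. The expected step of a 1.5-fold higher number from compound 3 to compound 4 (0.17 log units; within the scatter) is therefore a small rise in the number, close to the scatter, placing compound 4 between compound 3 and compound 1. Compound 4 is estimated at 40 nM, with a range from 15 nM to 120 nM.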

Compound 4, half-maximal inhibitory concentration: 100 nM
Compound 4: the middle estimate sits 2.5-fold (0.40 log units) below what was measured; the range from low to high includes it.
By their numbers in this assay, from the lowest: compound 3; then compounds 1, 2 and 4 (each within the scatter of the next).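

Placing 1H-1,2,4-triazol-1-yl in place of methylcarbamoyl on the saturated ring carbon gives a 3.7-fold higher number from compound 3 to compound 4 (0.57 log units; beyond the scatter) and lies beyond the scatter, so in this assay this position does not accept every group equally, even one with more heavy atoms and more hydrogen-bond acceptors. Set against methoxy, the same five-membered aromatic ring gives a 1.7-fold higher number from compound 1 to compound 4 (0.24 log units; within the scatter) and stays within the scatter, which means that among these three groups only methylcarbamoyl stands apart, while the triazole offers no measurable gain over the simpler methoxy. No measurement shown here explains why methylcarbamoyl and the triazole differ at this carbon.

The change removes the hydrogen-bond donor of methylcarbamoyl and its carbonyl together with it, so these compounds cannot show which part of the amide goes with the lower number of compound 3. A dimethylcarbamoyl group, an unsubstituted carboxamide or a carboxylic acid on the same carbon would separate those parts, and a primary amine or a 1,2,3-triazole would show how far the trend reaches beyond these three groups.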